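The compounds below may be only part of what the source reports. "The series", "measured", "known", "first", "only" and "open" are said of these compounds alone.

Working notes on the series

The shared core is carried unchanged through the set; only the aryl group on the amine nitrogen varies. Compound 1 `CCCCOc1ccc(Nc2nc3nonc3nc2O)cc1` gives 3700 nM in an assay on mitochondria from L6 cells (Rattus norvegicus) for activation, with a stated time of 90 min; on this read-out higher numbers stand for an effect only at larger amounts of compound and lower numbers for an effect already at smaller amounts. Within the data shown here, compound 2 `Oc1nc2nonc2nc1Nc1ccc(OCc2ccccc2)cc1` gives 2400 nM in this assay, and the one step measured so far, a 1.5-fold lower number from compound 1 to compound 2 (0.19 log units; within the scatter), sits within the scatter. Compound 3 `Oc1nc2nonc2nc1Nc1cccc(S(F)(F)(F)(F)F)c1` gives 3700 nM in this assay; this is level with compound 1 at the digits shown, and the two are together the highest of the three numbers, while compound 2 lies within the scatter of compound 3 as well. Across the three compounds no step beyond the scatter has appeared.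

Compound 4 `Oc1nc2nonc2nc1Nc1ccccc1` differs from compound 3 in one place: a hydrogen atom in place of a group of 6 heavy atoms (5 fluorine, 1 sulfur; no ring), on an aromatic carbon. Among the measured compounds shown here, no measured step removes a substituent from the aryl ring itself; the only step in hand, a 1.5-fold lower number from compound 1 to compound 2 (0.19 log units; within the scatter), concerns the chain carbon bound to the ring oxygen and was within the scatter. There is therefore no measured ground for a step in either direction, and none beyond the scatter is expected in this assay. The estimated step is no change at the digits printed from compound 3 to compound 4 (within the scatter). For compound 4 the expected value in this assay is 3700 nM, with a range of 1500 nM to 9500 nM.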

Compound 4, half-maximal effective concentration: 66700 nM
Compound 4: the middle estimate sits 18-fold (1.26 log units) below what was measured; the measured number lies above the stated range.
By their numbers in this assay, from the lowest: compounds 2, 1 and 3 (each within the scatter of the next); then compound 4.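

Among these compounds, putting hydrogen on the aromatic carbon in place of the group of 6 heavy atoms gives the first step beyond the scatter (an 18-fold higher number from compound 3 to compound 4 (1.26 log units; beyond the scatter)) in this assay, so a substituent on this aryl ring matters to the read-out in a way the earlier comparisons could not show. The same holds for hydrogen in place of benzyloxy (a 28-fold higher number from compound 2 to compound 4 (1.44 log units; beyond the scatter)) and hydrogen in place of butoxy (an 18-fold higher number from compound 1 to compound 4 (1.26 log units; beyond the scatter)), which means that three different groups, whose numbers lie within the scatter of one another, all stand apart from the unsubstituted aryl ring of compound 4 in this assay. Nothing in hand gives a measured reason for these steps.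

The compounds shown leave open whether a single atom or short group on the ring, such as chlorine, methyl or methoxy, would already bring the number back to the level of the three substituted compounds, or whether an amine or a carboxylic acid would do the same. They also leave open how far the number depends on which aromatic carbon carries the group, since no single group appears here on more than one carbon of the ring.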